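This account rests on a few compounds, and the source may have more. Where it says the series, first, only, none or still open, it means among the compounds named here.

Measured in a functional assay on MDA-MB-231 cells (Homo sapiens) for antiproliferative activity, read by XTT assay; on this read-out lower numbers stand for stronger inhibition and higher numbers for weaker inhibition:
compound 1 `CC(C)CCOc1cccc2occ(Cc3coc4ccccc4c3=O)c(=O)c12` gives > 10000 nM, a limit of the assay and not a number.
compound 2 `COc1ccc2c(=O)c(Cc3coc4cccc(OCC5CCCCC5)c4c3=O)coc2c1` gives 1200 nM.
compound 3 `O=c1c(Cc2coc3cccc(OCC4CCCCC4)c3c2=O)coc2cc(O)ccc12` gives 3220 nM.

Compound 1 therefore stands apart: its value is only a limit (the limit of > 10000 nM in this assay, at which 1 of the 3 values shown sits), whereas compound 2 and compound 3 carry numbers. Between those two lies the single measured step, a 2.7-fold higher number from compound 2 to compound 3 (0.43 log units; beyond the scatter), and it bears on the change followed here. Compound 4 `O=c1c(Cc2coc3cccc(O)c3c2=O)coc2ccccc12` differs from compound 1 by hydrogen in place of isopentyl on an oxygen on an aromatic ring, isopentyloxy becoming hydroxy, a related exchange of an alkyl for hydrogen on an aromatic oxygen. The measured step points to weaker inhibition or to no change beyond the scatter. Because compound 1 already sits at the limit (the limit of > 10000 nM in this assay, at which 1 of the 3 values shown sits), compound 4 is expected to remain at or beyond it, giving a step that the limit leaves unreadable from compound 1 to compound 4. The estimate for compound 4 is 20000 nM, with a range from 8000 nM to 60000 nM.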

Compound 4, half-maximal inhibitory concentration: > 10000 nM
Compound 4: only a limit was reported; the forecaster's own chance of this, stated with the estimate: 75%; the middle value lies beyond the limit too.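

Among these compounds, compound 1 and compound 4 both carry only a limit, so no step between them can be read: the limit of > 10000 nM in this assay, at which 2 of the 4 values shown sit. In this assay the compounds shown leave open whether isopentyloxy and hydroxy differ at all.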